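The compounds below may be only part of what the source reports. "The series", "measured", "known", "first", "only" and "open" are said of these compounds alone.

Compound 1 `Clc1ccc(NCc2cncn2Cc2ccc(-c3ccccc3)cc2)cc1-c1ccccc1` is examined in a toxicity assay on NIH3T3 cells (Mus musculus) for cytotoxicity, read by resazurin assay; a lower number here means that less compound is needed, a higher number that more compound is needed for the effect. In this assay compound 1 gives only a limit, > 1000 nM. Compound 2 `Nc1cc(-c2ccccc2)ccc1Cn1cncc1CNc1ccc(Cl)c(-c2ccccc2)c1` likewise gives only a limit in this assay, > 1000 nM. Among the measured compounds shown here, the single step between measured compounds, a step that the two limits leave unreadable from compound 1 to compound 2, is therefore not readable, because of the limit of > 1000 nM in this assay, at which 2 of the 3 values shown sit. For compound 3 `COC(=O)c1ccc(NCc2cncn2Cc2ccccc2F)cc1-c1ccccc1` the outcome in this assay is "not determined" (no result reported). Compound 4 `c1ccc(-c2ccc(Cn3cncc3CNc3ccc(-c4cc5ccccc5o4)c(-c4ccccc4)c3)cc2)cc1` differs from compound 1 by 1-benzofuran-2-yl in place of chloro on an aromatic carbon. For the measured compounds named here, no measured step bears on this change, and compound 1 itself stands only at a limit, so no direction can be read from the data. Compound 4 is thus expected to give 3000 nM in this assay, within a range from 1000 nM to 10000 nM. The expected step that the limit leaves unreadable from compound 1 to compound 4 would most likely again leave only a limit to report.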

Compound 4, half-maximal effective concentration: > 10000 nM
Compound 4 was reported as a limit (the forecaster's own chance of this, stated with the estimate: 70%); middle value at least 3.3-fold (0.52 log units) from the limit.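

In this assay, among the compounds shown here, compound 1 and compound 4 both stand only at limits, and no step between them can be read. The compounds shown leave open whether 1-benzofuran-2-yl in place of chloro changes the concentration needed at all.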